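Side-chain shortening from compound 1 to compound 4

This account rests on a few compounds, and the source may have more. Where it says the series, first, only, none or still open, it means among the compounds named here.

Measured in a functional assay on L1210 cells (Mus musculus) for cytotoxicity (a lower number here means that less compound is needed, a higher number that more compound is needed for the effect), so far:
compound 1 `CCCC(O)C1=CC(=O)c2c(OC)ccc(OC)c2C1=O` gives 0.409 ug/mL
compound 2 `COc1cc(CO)c(OC)c2c1C(=O)C=CC2=O` gives 0.062 ug/mL
compound 3 `COc1cc(C(C)O)c(OC)c2c1C(=O)C=CC2=O` gives 0.132 ug/mL

Compound 1 stands at the highest of the three numbers; compound 3 is nearest to it, compound 2 furthest, and both gaps lie beyond the scatter. For the measured compounds named here, the one step between compounds that differ in a single place is a 2.1-fold higher number from compound 2 to compound 3 (0.33 log units; beyond the scatter): a methyl added at the hydroxyl-bearing chain carbon raised the number modestly.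

Compound 4 `CCC(O)C1=CC(=O)c2c(OC)ccc(OC)c2C1=O` is the next candidate. Against compound 1 the difference is hydrogen in place of methyl on a saturated chain carbon, three bonds along the chain from a double-bonded ring carbon and an oxygen on a saturated carbon. The measured step is the only one that bears on this, and it does so loosely: there the methyl sits at the hydroxyl-bearing carbon, here it sits at the chain end. Read in reverse, that step suggests that taking a methyl away lowers the number by a modest amount, so in this assay a small step downward, or none beyond the scatter, is expected for compound 4.

For compound 4 the expected value in this assay is 0.3 ug/mL, with a range from 0.12 ug/mL to 0.8 ug/mL. The step that this estimate means is a 1.4-fold lower number from compound 1 to compound 4 (0.13 log units; within the scatter).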

Compound 4, concentration for half-maximal effect: 0.516 ug/mL
Estimate against measurement, compound 4: 1.7-fold (0.24 log units) below, and the stated range covers the measured number.
By their numbers in this assay, from the lowest: compound 2; then compound 3; then compounds 1 and 4 (each within the scatter of the next).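

In this assay, going from 1-hydroxybutyl to 1-hydroxypropyl on the shared core gives a 1.3-fold higher number from compound 1 to compound 4 (0.10 log units; within the scatter), so the loss of this methyl, three bonds along the chain from a double-bonded ring carbon and an oxygen on a saturated carbon, does not register in the number. Hydrogen in place of methyl therefore does not read alike in the two places, and the step seen at the hydroxyl-bearing carbon does not transfer to the chain end: the same change on two cores in this assay, a 2.1-fold higher number (0.33 log units; beyond the scatter) from compound 2 to compound 3 and a 1.3-fold lower number (0.10 log units; within the scatter) from compound 4 to compound 1, 2.7-fold (0.43 log units) apart, beyond the scatter of two such steps

Within this pair, the choice between 1-hydroxypropyl and 1-hydroxybutyl offers no handle on the number in this assay.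

Still open, from the compounds shown here alone, is whether this flat response holds for a longer chain such as 1-hydroxypentyl, or for a chain end carrying an amine or a carboxylic acid. The compounds shown also leave unsettled what the hydroxyl itself contributes on the core of compound 1, a question that a methoxy or a carbonyl at that chain carbon would address.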